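The source may report more compounds than this note shows. Statements on the series, on what has been measured and on what is new or still open speak of the compounds shown alone.

Measured so far:
Compound 1, `COc1cccc(Cc2cc(-c3cccs3)nn(CC(=O)Nc3ccc(F)cc3)c2=O)c1`: > 50000 nM
Compound 2, `COc1cccc(Cc2cc(-c3ccc(Cl)cc3)nn(CC(=O)Nc3ccc(F)cc3)c2=O)c1`: > 50000 nM

In a functional assay on HL-60 cells (Homo sapiens), read by calcium flux (on this read-out higher numbers stand for an effect only at larger amounts of compound and lower numbers for an effect already at smaller amounts), compound 1 gives > 50000 nM, which is a limit of the assay rather than a number. Compound 2 gives > 50000 nM in this assay, again a limit and not a number. Both values sit at the limit of > 50000 nM in this assay, at which 2 of the 2 values shown sit. The step from compound 1 to compound 2, a step that the two limits leave unreadable from compound 1 to compound 2, therefore cannot be read in either direction or size.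

Compound 3, `COc1cccc(Cc2cc(-c3ccc(C)cc3)nn(CC(=O)Nc3ccc(F)cc3)c2=O)c1`, differs from compound 2 by methyl in place of chloro on an aromatic carbon. Going by the values given here, only the unreadable step from compound 1 to compound 2 touches the same position, so no measured step tells how large a change to expect in this assay. The plainest expectation is that compound 3 stays where compound 2 stands, at the limit, so compound 3 is estimated at 50000 nM with a range from 10000 nM to 250000 nM. The expected step from compound 2 to compound 3 is then a number no higher from compound 2 to compound 3 (the limit leaves the size open).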

Compound 3, half-maximal effective concentration: > 50000 nM
Compound 3 ended at the assay's limit; the forecaster's own chance of this, stated with the estimate: 80%; the middle value sits exactly at the limit.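

Compound 3 gives > 50000 nM in this assay, a limit and not a number. None of the steps among compound 1, compound 2 and compound 3 can be read. The compounds shown leave open whether thiophen-2-yl, 4-chlorophenyl and 4-methylphenyl differ in effect at all.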